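This account rests on a few compounds, and the source may have more. Where it says the series, first, only, none or still open, it means among the compounds named here.

Compound 1 (`CN(C)c1ccc(CNC(=O)c2nc(Br)c3cccnc3c2N[C@H]2CC[C@H](N)CC2)cc1`) is the starting point here, yet in a functional assay on HCT-116 cells (Homo sapiens) for cytotoxicity, read by MTT assay, with a stated time of 72 h (a lower number here means a stronger inhibitor, a higher number a weaker inhibitor), compound 1 has no reported result ("not determined" (no result reported)), so no number places it among the others. Two related compounds carry numbers in this assay. Compound 2 (`CNCCCNc1c(C(=O)NCc2ccc(F)cc2)nc(Br)c2cccnc12`) gives 9000 nM in this assay. Compound 3 (`NCCCNc1c(C(=O)NCc2ccc(F)cc2)ncc2cccnc12`) reaches only the limit of this assay, reported as > 10000 nM, which is a boundary of the measurement and not a number. That limit is also the mark at which one of the three values sits (the limit of > 10000 nM in this assay, at which 1 of the 3 values shown sits).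

Compound 4 (`N[C@H]1CC[C@H](Nc2c(C(=O)Nc3ccccc3)nc(Br)c3cccnc23)CC1`) is the compound still to be measured. It differs from compound 1 in one place: phenyl in place of 4-(dimethylamino)benzyl on an amide-type nitrogen. In words, phenyl replaces 4-(dimethylamino)benzyl on the amide-type nitrogen whose other neighbour is the carbonyl carbon.

Within the data shown here, no measured pair in this set shares only this change, so the size of the step from compound 1 to compound 4 in this assay cannot be read from the data. With no number for compound 1, the expectation rests on compound 2 and compound 3, both weak, and no direction beyond the scatter is expected. Compound 4 is therefore estimated at 8000 nM, within a range from 2000 nM to 30000 nM.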

Compound 4, half-maximal inhibitory concentration: 2000 nM
The estimate for compound 4 lay 4.0-fold (0.60 log units) above the measured number; low and high end bracket the measured number.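

No step can be read from the value of compound 4: compound 1 has no number in this assay, and compound 2 and compound 3 differ from compound 4 in more than one place. Nothing shown accounts for the result for compound 4. On these data alone, what replacing 4-(dimethylamino)benzyl with phenyl does to the read-out remains open.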